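The source may hold more compounds than are shown below. What is called first, only, known or untested is meant among the compounds shown, and "the series" means these compounds.

Measured compounds:
compound 1 `O=C1COc2ccc(-c3cnc(Cl)c(NS(=O)(=O)c4ccc(F)cc4)c3)cc2N1c1ccccc1`: 36900 nM
compound 2 `O=C1COc2ccc(-c3cnc(Cl)c(NS(=O)(=O)c4ccc(F)cc4)c3)cc2N1C1CCCCC1`: > 40000 nM, a limit of the assay
compound 3 `CC(C)N1C(=O)COc2ccc(-c3cnc(Cl)c(NS(=O)(=O)c4ccc(F)cc4)c3)cc21`: 25500 nM

All three share one core and differ only in the group on an amide-type nitrogen in a ring. In a functional assay on A-375 cells (Homo sapiens) for antiproliferative activity, read by MTT assay, with a stated time of 72 h (a higher number here means a weaker inhibitor, a lower number a stronger inhibitor), compound 3 gives 25500 nM, the lowest of the two numbers given. Within the data shown here, the one step between two numbers is a 1.4-fold lower number from compound 1 to compound 3 (0.16 log units; within the scatter), which stays within the scatter. For compound 2 this assay reports only a limit, > 40000 nM (the limit of > 40000 nM in this assay, at which 1 of the 3 values shown sits). The steps of an at least 1.0-fold higher number from compound 1 to compound 2 (0.03 log units; that floor lies within the scatter) and an at least 1.5-fold lower number from compound 2 to compound 3 (0.19 log units; that floor lies within the scatter) therefore set only floors, both within the scatter.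

Compound 4 `Cc1ccc(N2C(=O)COc3ccc(-c4cnc(Cl)c(NS(=O)(=O)c5ccc(F)cc5)c4)cc32)cc1` differs from compound 3 by 4-methylphenyl in place of isopropyl on an amide-type nitrogen in a ring. The step that bears on it is a 1.4-fold lower number from compound 1 to compound 3 (0.16 log units; within the scatter), since 4-methylphenyl is closer to phenyl than to isopropyl; that step was small, so the return is expected to be small as well, with a number a little higher, a 1.4-fold higher number from compound 3 to compound 4 (0.14 log units; within the scatter). Compound 4 is thus expected to give about 35000 nM in this assay, between 18000 nM and 70000 nM, with some chance that only a limit is reported.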

Compound 4, half-maximal inhibitory concentration: 38900 nM
Estimate against measurement, compound 4: 1.1-fold (0.05 log units) below; measured number inside the range.
By their numbers in this assay, from the lowest: compounds 3, 1 and 4 (each within the scatter of the next). At a limit, above all of these: compound 2.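

In this assay, methyl in place of hydrogen on an aromatic carbon of the phenyl group leaves the number unresolved from that of the parent, a 1.1-fold higher number from compound 1 to compound 4 (0.02 log units; within the scatter). Among these compounds, the larger exchange at this position, 4-methylphenyl in place of isopropyl on the amide-type nitrogen, also stays inside the scatter, a 1.5-fold higher number from compound 3 to compound 4 (0.18 log units; within the scatter), so compounds 1, 3 and 4 now show an alkyl group, an aromatic ring and a methyl-bearing aromatic ring here with no step among them beyond the scatter. Compound 2 remains a limit, and the step of an at least 1.0-fold lower number from compound 2 to compound 4 (0.01 log units; that floor lies within the scatter) sets only a floor: the limit of > 40000 nM in this assay, at which 1 of the 4 values shown sits.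

Going by these compounds, whether any group on this nitrogen can move the number beyond the scatter stays open. A plain hydrogen, a chain ending in an amine or a carboxylic acid, or a methoxy group on the phenyl ring would each test this.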